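The source may report more compounds than this note shows. Statements on the series, on what has been measured and on what is new or still open speak of the compounds shown alone.

Measured compounds: compound 1 `CC1CCN(C(=S)SCc2ccc(C(=O)Nc3ccccc3N)cc2)CC1`, compound 2 `Nc1ccccc1NC(=O)c1ccc(CSC(=S)N2CCN(Cc3ccccc3)CC2)cc1` and compound 3 `Nc1ccccc1NC(=O)c1ccc(CSC(=S)N2CCN(Cc3cccnc3)CC2)cc1`.

In a functional assay on HeLa cells (Homo sapiens) for antiproliferative activity, read by CCK-8 assay, with a stated time of 72 h, tested at 8 uM (on this read-out higher numbers stand for a stronger effect at the one concentration tested and lower numbers for a weaker effect), compound 1 gives 72.5%, compound 2 gives 31.3% and compound 3 gives 78%. Compound 1 stands second highest of the three numbers; its gap to compound 3 lies within the scatter, while compound 2 sits far lower, beyond it. Among the measured compounds shown here, the only measured step, a number 46.7 percentage points higher from compound 2 to compound 3 (beyond the scatter), changes the aryl group on the chain carbon bound to the ring amine nitrogen and leaves the ring untouched.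

Compound 4 `CN1CCN(C(=S)SCc2ccc(C(=O)Nc3ccccc3N)cc2)CC1` differs from compound 1 by 4-methylpiperazin-1-yl in place of 4-methylpiperidin-1-yl on a thiocarbonyl carbon. For the measured compounds named here, no measured step changes this ring, so nothing in the data fixes the size of this step in this assay; compounds 2 and 3 show only that amines of this kind can sit high or low. A modest downward step of a number 12.5 percentage points lower from compound 1 to compound 4 (beyond the scatter) is expected, with wide uncertainty. Compound 4 is therefore estimated at 60%, within 35% to 85%.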

Compound 4, a percentage reported as inhibition, at one concentration (the size of the read-out at that concentration, not a potency): 75.7%
Beside the measured number, compound 4's estimate is 15.7 percentage points below it; the range from low to high includes it.
By their numbers in this assay, from the lowest: compound 2; then compounds 1, 4 and 3 (each within the scatter of the next).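

In this assay, 4-methylpiperazin-1-yl in place of 4-methylpiperidin-1-yl on the thiocarbonyl carbon gives a number 3.2 percentage points higher from compound 1 to compound 4 (within the scatter) and so leaves the read-out within the scatter. On the saturated chain carbon, hydrogen in place of pyridin-3-yl gives a number 2.3 percentage points lower from compound 3 to compound 4 (within the scatter), whereas hydrogen in place of phenyl gives a number 44.4 percentage points higher from compound 2 to compound 4 (beyond the scatter), so among these three groups only phenyl stands apart. No evidence offered here accounts for this. On these data alone, whether morpholin-4-yl would match these two rings on the thiocarbonyl carbon stays open, as does the effect of an ethyl or a carboxylic acid on that chain carbon.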